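The source may report more compounds than this note shows. Statements on the series, on what has been measured and on what is new or still open speak of the compounds shown alone.

Of the compounds shown here, three have so far been tested in a functional assay on T47D cells (Homo sapiens) for inhibition, read by CCK-8 assay, with a stated time of 72 h, tested at 10 uM; a lower number here means less inhibition of growth, a higher number more inhibition of growth at the concentration tested. Compound 1 (`CN(C)C(=O)c1cc2cnc(Nc3ccc(N)cn3)nc2n1C1CCCC1`) gives 61.1%, and compound 3 (`Nc1ccc(NC(=O)C2(C(=O)Nc3ccc(F)cc3)CC2)cc1F`) gives 30.4%. Compound 2 (`COc1ccc(NC(=O)C2(C(=O)Nc3ccc(Nc4ncc5cc(C(=O)N(C)C)n(C6CCCC6)c5n4)cc3)CC2)cc1`) gives 96.1%, the highest of the three numbers, and its gap to each of the other two lies beyond the usual scatter of such measurements.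

Compound 4 (`Cc1ccc(NC(=O)C2(C(=O)Nc3ccc(Nc4ncc5cc(C(=O)N(C)C)n(C6CCCC6)c5n4)cc3)CC2)cc1`) has not yet been measured. It differs from compound 2 in one place, on an aromatic carbon para to a large group, where 4-methoxyphenyl becomes 4-methylphenyl: methyl in place of methoxy on an aromatic carbon. Among the measured compounds shown here, no two measured compounds differ in only one place, so the data offer no direct precedent for this swap. For the measured compounds named here, compound 2 stands at 96.1%, close to the top of the scale, and only one small group changes, so no step beyond the scatter is expected, though a slight drop is possible. The estimated change is a number 4.1 percentage points lower from compound 2 to compound 4 (within the scatter), which stays within the scatter. For compound 4 the expected value is 92%, with an estimated range from 78% to 100%.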

Compound 4, percent growth inhibition at one concentration: 99.6%
The estimate for compound 4 lay 7.6 percentage points below the measured number; the range from low to high includes it.
By their numbers in this assay, from the lowest: compound 3; then compound 1; then compounds 2 and 4 (each within the scatter of the next).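

In this assay, among the compounds shown here, this is the first direct comparison at this position: methyl in place of methoxy gives a number 3.5 percentage points higher from compound 2 to compound 4 (within the scatter), so growth inhibition holds when the group on an aromatic carbon para to a large group changes. The swap removes the oxygen and its hydrogen-bond acceptor, and no loss beyond the scatter appears at the concentration tested. No measurement shown here explains why the two compounds read alike.

Both numbers lie close to the top of the scale, so a real difference between the two compounds could stay hidden in this single-concentration read-out. From the compounds shown here alone, it also remains open whether the same position would hold its inhibition with a different group there, such as an amine, a carboxylic acid or a longer chain.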